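A few compounds are considered here, and "the series" means these few. Any claim that something is new, unique, unknown or untested is made for them only; others in the source may bear on it.

Measured compounds in hand:
- compound 1, `COc1ccc(-c2c(C)nc3c(N4CC[C@@H](NC(C)=O)C4)cc(C)nn23)cn1`: > 95%
- compound 2, `COc1ccc(-c2c(C)nc3c(N4CC[C@@H](NC(=O)c5ccccc5)C4)cc(C)nn23)cc1OC`: > 95%

Both values are limits of the assay rather than numbers. In an ADME assay on microsomes from liver (Homo sapiens) for metabolic stability, read by LC-MS, with NADPH named in the record, with a stated time of 60 min, tested at 1 uM, in the absence of a further agent (a lower number here means that less of the compound is left, a higher number that more of the compound is left), compound 1 reports > 95%, a limit and not a measured number. Compound 2 likewise reports > 95%, again a limit. On the numbers shown, compound 2 therefore stands only at the top of what this assay resolves, alongside (the limit of > 95% in this assay, at which 2 of the 2 values shown sit), and no ordering between the two measured compounds can be read from these values.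

Compound 3, `COc1ccc(-c2c(C)nc3c(N4CC[C@@H](NS(=O)(=O)C5CC5)C4)cc(C)nn23)cc1OC`, is not yet measured in this assay. It differs from compound 2 in one place: cyclopropylsulfonyl in place of benzoyl on an amine nitrogen. For the measured compounds named here, no step between measured compounds is available that bears on this change, and the two measured values are limits, so nothing in the data shows the direction of its effect. The expectation for this assay is a small step, if any, downward from the limit and not beyond the usual scatter.

Compound 3 is expected to remain at about 92%, within 75% to 99%. The expected step is a number at least 3 percentage points lower from compound 2 to compound 3 (that floor lies within the scatter), small and likely within the scatter.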

Compound 3, percent of the compound remaining: > 95%
Compound 3 gave a limit, no number; the forecaster's own chance of this, stated with the estimate: 55%; middle value at least 3 percentage points from the limit.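

In this assay compound 3 gives > 95%, a limit and not a number. No step can be read between compound 2 and compound 3, because both sit at the same limit: the limit of > 95% in this assay, at which 3 of the 3 values shown sit.

The compounds shown leave open whether the group on the amine nitrogen influences the percent of compound remaining at all, since no value shown is a number.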